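The compounds below may be only part of what the source reports. "The series", "measured", "known", "first", "only" and "open" are said of these compounds alone.

Compound 2 `CC(=O)N1CCC(c2cnc(NCc3c(F)ccc4c3CCO4)c3cn[nH]c(=O)c23)CC1` and compound 1 `Cc1nccn1-c1cnc(NCc2c(F)ccc3c2CCO3)c2cn[nH]c(=O)c12` share one core and differ only in the group on an aromatic carbon. Within the data shown here, in an ADME assay on microsomes from liver (Homo sapiens) for metabolic stability, read by LC-MS, using NADPH, with stated times of 5 min and 30 min, tested at 1 uM (on this read-out lower numbers stand for slow clearance and higher numbers for fast clearance), compound 1 gives 8 mL.min-1.g-1, while compound 2 gives 207 mL.min-1.g-1, which is the higher of the two numbers known; the step of a 26-fold higher number from compound 1 to compound 2 (1.41 log units; beyond the scatter) is the only measured step so far. Compound 3 `Cc1ncccc1-c1cnc(NCc2c(F)ccc3c2CCO3)c2cn[nH]c(=O)c12` is the next compound to be measured. It differs from compound 2 in one place: 2-methylpyridin-3-yl in place of 1-acetylpiperidin-4-yl on an aromatic carbon. The entering group, like the 2-methyl-1H-imidazol-1-yl of compound 1, is a six-membered or five-membered aromatic ring with one hetero atom, whereas the leaving group is the non-aromatic ring that came with the large rise in a 26-fold higher number from compound 1 to compound 2 (1.41 log units; beyond the scatter). A large fall is therefore expected, roughly reversing that step, estimated as a 10-fold lower number from compound 2 to compound 3 (1.01 log units; beyond the scatter). Compound 3 is accordingly expected to give about 20 mL.min-1.g-1 in this assay, within a range of 6 mL.min-1.g-1 to 70 mL.min-1.g-1.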

Compound 3, intrinsic clearance in microsomes: 41 mL.min-1.g-1
For compound 3 the middle estimate is 2.1-fold (0.31 log units) below the measured one; low and high end bracket the measured number.
By their numbers in this assay, from the lowest: compound 1; then compound 3; then compound 2.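

In this assay, putting the aromatic 2-methylpyridin-3-yl in place of the non-aromatic 1-acetylpiperidin-4-yl gives a 5.0-fold lower number from compound 2 to compound 3 (0.70 log units; beyond the scatter) on the same core, so a fall on leaving the piperidine ring is not confined to the 2-methyl-1H-imidazol-1-yl group. The two aromatic groups are still not interchangeable, since 2-methylpyridin-3-yl in place of 2-methyl-1H-imidazol-1-yl gives a 5.1-fold higher number from compound 1 to compound 3 (0.71 log units; beyond the scatter) in the same read-out. At this position, then, clearance depends on more than whether the ring is aromatic: compound 3 falls between compound 1 and compound 2, with each gap beyond the scatter.

Nothing available explains these differences. As far as these compounds go, it also remains open how a pyridin-3-yl without the methyl, a plain phenyl or a simple amine would behave at this position.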